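Succinimide-substituted arylpiperazine amides in the electroshock model

The compounds below may be only part of what the source reports. "The series", "measured", "known", "first", "only" and "open" are said of these compounds alone.

Measured so far:
compound 1 `CC(C(=O)N1CCN(c2ccc(Cl)cc2)CC1)N1C(=O)CCC1=O` — 50%
compound 2 `CCC(C(=O)N1CCN(c2cccc(C(F)(F)F)c2)CC1)N1C(=O)CCC1=O` — 75%

In a functional assay on the whole organism (strain Swiss) with Mus musculus as the target, in the maximal electroshock model, with a stated time of 0.25 h, at a dose of 100 mg/kg by the intraperitoneal route (a higher number here means a stronger effect of the compound at the dose given, a lower number a weaker effect), compound 1 gives 50%, the lower of the two numbers. Compound 2 gives 75%, a figure that lies beyond the scatter above it. Among the measured compounds shown here, no single-change step between these two is available, since they differ in more than one place, so their two values show only that compound 2 reads higher.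

Compound 3 `CC(C(=O)N1CCN(c2cccc(Cl)c2)CC1)N1C(=O)CCC1=O` is not yet measured. It has the same atoms as compound 1 joined differently: 3-chlorophenyl in place of 4-chlorophenyl on an amine nitrogen in a ring. For the measured compounds named here, no measured pair isolates this kind of change, so there is no basis for a directional expectation; a step from compound 1 to compound 3 within the scatter is expected, in either direction. Compound 3 is estimated at 55%, with a range from 25% to 85%, which means an expected step of a number 5 percentage points higher from compound 1 to compound 3 (within the scatter).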

Compound 3, a percentage reported as activity, at one dose (the size of the read-out at that dose, not a potency): 50%
For compound 3 the middle estimate is 5 percentage points above the measured one; measured number inside the range.
By their numbers in this assay, from the lowest: compounds 1 and 3 (each within the scatter of the next); then compound 2.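

In this assay, among the compounds shown here, 3-chlorophenyl in place of 4-chlorophenyl on the amine nitrogen in a ring gives no change at the digits printed from compound 1 to compound 3 (within the scatter), the first single-change step. With the rest of the core of compound 1 held fixed, this read-out at this one dose therefore does not separate the two chlorophenyl groups, which the differing pair of compound 1 and compound 2 could not show. Nothing measured bears on the reason for this result.

Open, from the compounds shown here alone, is whether a methoxy group or a fluorine in place of the chlorine on the phenyl ring would also leave the read-out within the scatter. Also open, going by these compounds, is whether the 3-chlorophenyl and 4-chlorophenyl groups would still read alike with a propyl chain on the carbon that carries the succinimide.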